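Chloro to Benzyloxy at the Para Position of Compound 3

A few compounds are considered here, and "the series" means these few. Any claim that something is new, unique, unknown or untested is made for them only; others in the source may bear on it.

Compound 1, `Nc1nc(O)c2c(n1)n(C1OC(CO)[C@@H](O)[C@H]1O)c(=O)n2CC(O)CSc1ccccc1`, gives 142 uM in a functional assay (B cells) with Mus musculus as the target; a higher number here means that more compound is needed for the effect, a lower number that less compound is needed.
Compound 2, `COc1ccc(Cn2c(=O)n(C3OC(CO)[C@@H](O)[C@H]3O)c3nc(N)nc(O)c32)cc1`, gives 135 uM.
Compound 3, `Nc1nc(O)c2c(n1)n(C1OC(CO)[C@@H](O)[C@H]1O)c(=O)n2Cc1ccc(Cl)cc1`, gives 14 uM.

Compound 3 holds the lowest number of the three. The step of a 9.6-fold lower number from compound 2 to compound 3 (0.98 log units; beyond the scatter) sets it apart from compound 2, and the step of a 10-fold lower number from compound 1 to compound 3 (1.01 log units; beyond the scatter) from compound 1, both beyond the scatter, so compound 3 is the most potent of the measured set. Between compound 1 and compound 2 the step of a 1.1-fold lower number from compound 1 to compound 2 (0.02 log units; within the scatter) lies within the scatter, and no order can be read there.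

The unmeasured compound 4, `Nc1nc(O)c2c(n1)n(C1OC(CO)[C@@H](O)[C@H]1O)c(=O)n2Cc1ccc(OCc2ccccc2)cc1`, differs from compound 3 by benzyloxy in place of chloro on an aromatic carbon. Going by the values given here, the one measured step that touches this position is a 9.6-fold lower number from compound 2 to compound 3 (0.98 log units; beyond the scatter), where chloro in place of methoxy brought a large fall in the number. Benzyloxy resembles methoxy in carrying one hydrogen-bond acceptor, yet its added ring has no counterpart among the measured compounds, so the size of the effect is uncertain. Compound 4 is therefore expected to give a higher number than compound 3, a step of about a 2.9-fold higher number from compound 3 to compound 4 (0.46 log units; beyond the scatter). The estimate for compound 4 is 40 uM, with a range from 8 uM to 200 uM.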

Compound 4, concentration for half-maximal effect: 8 uM
The estimate for compound 4 lay 5.0-fold (0.70 log units) above the measured number; low and high end bracket the measured number.
By their numbers in this assay, from the lowest: compounds 4 and 3 (each within the scatter of the next); then compounds 2 and 1 (each within the scatter of the next).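

In this assay, the step of a 1.8-fold lower number from compound 3 to compound 4 (0.24 log units; within the scatter) lies within the scatter, so chloro and benzyloxy cannot be told apart on this aromatic carbon, even though benzyloxy brings 8 heavy atoms and a six-membered aromatic ring where chloro has 1 heavy atom. The step of a 17-fold lower number from compound 2 to compound 4 (1.23 log units; beyond the scatter) lies beyond the scatter, so adding a phenyl to the methoxy group of compound 2 is enough to separate the two compounds, and compound 4 goes against any reading that an oxygen on this aromatic carbon brings the higher number seen for compound 2. Nothing given here accounts for either result.

The compounds shown leave open whether the ring of benzyloxy or its oxygen is what matters, as a phenyl placed directly on this aromatic carbon or a longer chain such as 2-phenylethoxy could give a number like that of compound 4 or like that of compound 2. They also leave open how an amine or a carboxylic acid on this same carbon would compare with chloro and benzyloxy.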